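Naphthalene amide series: ester replaced by chlorobenzyl

The compounds below may be only part of what the source reports. "The series", "measured", "known", "first", "only" and "open" are said of these compounds alone.

Measured so far:
compound 2 `CC(C)(C)OC(=O)CN(Cc1ccc([N+](=O)[O-])s1)C(=O)c1cccc2ccccc12`: 2600 nM
compound 3 `CC(C)(C)OC(=O)CN(Cc1ccc([N+](=O)[O-])s1)S(=O)(=O)c1cccc2ccccc12`: 800 nM
compound 1 `CC(C)(C)OC(=O)CN(Cc1ccc2ccccc2c1)Cc1ccc([N+](=O)[O-])s1`: "not determined" (no result reported)

In a functional assay on HEK293 cells for agonist activity at nuclear receptor subfamily 1 group D member 1 (Homo sapiens), read by a luciferase reporter, with a stated time of 24 h (a higher number here means that more compound is needed for the effect, a lower number that less compound is needed), compound 2 gives 2600 nM, the higher of the two numbers obtained. Compound 3 gives 800 nM, a lower number, and the gap between compound 2 and compound 3 lies beyond the scatter of repeated measurements. Compound 1 carries the same nitrothiophene arm on its nitrogen, but in this assay compound 1 stands at "not determined" (no result reported), so it adds nothing to the comparison.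

Compound 4 `O=C(c1cccc2ccccc12)N(Cc1ccc(Cl)cc1)Cc1ccc([N+](=O)[O-])s1` is not yet measured. Relative to compound 2 the change is 4-chlorophenyl in place of tert-butoxycarbonyl on a saturated chain carbon bound to an amide-type nitrogen; read one bond further out, a (tert-butoxycarbonyl)methyl arm becomes a 4-chlorobenzyl arm, while the naphthoyl amide and the nitrothiophene arm are kept. Among the measured compounds shown here, no measured pair isolates this exchange, so there is no recorded step to lean on.

The expectation for compound 4 is a modest move toward a lower number than compound 2, of a size that may not exceed the scatter, with the estimate for compound 4 in this assay placed at 1500 nM within the range 400 nM to 6000 nM, which corresponds to an expected step of a 1.7-fold lower number from compound 2 to compound 4 (0.24 log units; within the scatter).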

Compound 4, half-maximal effective concentration: 2600 nM
Compound 4: the middle estimate sits 1.7-fold (0.24 log units) below what was measured; the range from low to high includes it.
By their numbers in this assay, from the lowest: compound 3; then compounds 2 and 4 (each within the scatter of the next).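

In this assay, among the compounds shown here, the exchange of tert-butoxycarbonyl for 4-chlorophenyl on a saturated chain carbon bound to an amide-type nitrogen gives no change at the digits printed from compound 2 to compound 4 (within the scatter) and is the first step recorded at this place. The ester is therefore not required to hold this reading with the naphthoyl amide and nitrothiophene arm kept: an arm with no hydrogen-bond acceptors, an aromatic ring and a chlorine takes the place of the (tert-butoxycarbonyl)methyl arm, with the same number of heavy atoms in the exchanged group. Nothing at hand bears on why the two arms read alike.

Going by these compounds, it remains open whether the 4-chlorobenzyl arm would give the same result on the sulfonyl-linked compound 3, which stands at 800 nM, and thus whether this tolerance holds beyond the naphthoyl amide. Also open, on these data alone, is how a carboxylic acid, an unsubstituted benzyl or a longer alkyl chain at this place would read, and with that whether the chlorine contributes anything to the reading of compound 4.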